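Methylsulfanyl in Place of Methyl on a Quinolinone Amide

The source may hold more compounds than are shown below. What is called first, only, known or untested is meant among the compounds shown, and "the series" means these compounds.

Compound 1 `CCN(C(=O)c1c(O)c2c(C)cccc2n(C)c1=O)c1ccccc1` was examined in a functional assay on the whole organism for inhibition, with Mus musculus as the target, at a dose of 1 mg/kg by the oral route (a higher number here means more inhibition at the dose given (going by the name of the read-out), a lower number less inhibition), where compound 1 gives 65%. This is the lower of the two numbers available, since compound 2 `COc1ccc(N(C)C(=O)c2c(O)c3c(OC)cccc3n(C)c2=O)cc1` in this assay gives 84%, a reading that lies beyond the usual scatter above that of compound 1. For the measured compounds named here, no single-point step connects these two measured compounds, so their values are simply reported side by side.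

Compound 3 `CCN(C(=O)c1c(O)c2c(SC)cccc2n(C)c1=O)c1ccccc1` has not yet been measured. It differs from compound 1 in one place: methylsulfanyl in place of methyl on an aromatic carbon. Going by the values given here, no measured pair shows what such a change does here, so any expectation rests on compound 1 alone. The change is small, and a step from compound 1 to compound 3 of about a number 3 percentage points higher from compound 1 to compound 3 (within the scatter) is expected, which is to say none beyond the scatter of repeated measurements. Compound 3 is therefore estimated at 68%, with a likely range from 50% to 85%.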

Compound 3, a percentage reported as inhibition, in the whole organism at one dose (the size of the read-out at that dose, not a potency): 73%
Estimate against measurement, compound 3: 5 percentage points below; low and high end bracket the measured number.
By their numbers in this assay, from the lowest: compounds 1 and 3 (each within the scatter of the next); then compound 2.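

In this assay, placing methylsulfanyl on this aromatic carbon in place of methyl gives a number 8 percentage points higher from compound 1 to compound 3 (within the scatter). This first measured pair for the change shows that, on the core of compound 1, this position takes methylsulfanyl, with its sulfur and its hydrogen-bond acceptor, without a shift beyond the scatter. Nothing available explains why the two groups read alike at the dose given.

The compounds shown leave open whether an amine, a carboxylic acid or a longer chain such as ethylsulfanyl on this same carbon would also stay within the scatter of compound 1. They also leave open whether compound 1 and compound 3 would remain this close at other doses, since a single-dose reading is not a potency.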